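Lengthening the Chain on the Shared Core of Compound 2

The source may hold more compounds than are shown below. What is called first, only, known or untested is meant among the compounds shown, and "the series" means these compounds.

Compound 2 `Nc1nc(CCc2ccccc2)nc2cn(-c3ccccc3)nc12` carries a chain ending in a phenyl on its shared core; in an assay on CHO cells for displacement of a labelled ligand from adenosine receptor A3 (Homo sapiens), read by scintillation counting, tested at 1 uM (a lower number here means less inhibition, a higher number more inhibition at the concentration tested (going by the name of the read-out)), compound 2 gives 17%. Going by the values given here, of the two numbers measured so far, that of compound 2 is the higher, though the gap to the other lies within the scatter: compound 1 `CC(C)Cc1nc(N)c2nn(-c3ccccc3)cc2n1` gives 13% in this assay, and the step of a number 4 percentage points higher from compound 1 to compound 2 (within the scatter) does not separate the two compounds. Compound 3 `COc1ccc(CCCc2nc(N)c3nn(-c4ccccc4)cc3n2)cc1` has not yet been tested. It differs from compound 2 in one place: 4-methoxybenzyl in place of phenyl on a saturated chain carbon, two bonds along the chain from an aromatic carbon. Among the compounds with values here, the only measured step that bears on this change is the one from compound 1 to compound 2, which also reshaped the chain attached to the core and stayed within the scatter. With just one step to draw on, and that one flat, no movement beyond the scatter is expected in this assay; the expected step is a number 3 percentage points higher from compound 2 to compound 3 (within the scatter). Compound 3 is therefore estimated at 20% in this assay, with a range from 5% to 40%.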

Compound 3, a percentage reported as inhibition, at one concentration (the size of the read-out at that concentration, not a potency): 1%
The estimate for compound 3 lay 19 percentage points above the measured number; measured number outside the range, below it.
By their numbers in this assay, from the lowest: compound 3; then compounds 1 and 2 (each within the scatter of the next).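

This change is the first among the compounds shown to move the number in this assay beyond the scatter: the step is a number 16 percentage points lower from compound 2 to compound 3 (beyond the scatter) on going to 4-methoxybenzyl in place of phenyl on a saturated chain carbon, two bonds along the chain from an aromatic carbon. The earlier change in the chain, a number 4 percentage points higher from compound 1 to compound 2 (within the scatter), did not separate its two compounds, so the flat result there did not carry over to this position, where the entering group, with 9 heavy atoms against 6 and one hydrogen-bond acceptor against none, goes with less inhibition at the concentration tested. Nothing available here accounts for this drop.

The compounds shown leave open whether the drop goes with the extra length of the chain or with the methoxy group, as the two enter together in this single change. Also open, going by these compounds, is how this assay would read with a plain benzyl at this place, or with a hydroxyl group, an amine or a carboxylic acid on the ring in place of the methoxy group.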